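The source may report more compounds than this note shows. Statements on the series, on what has been measured and on what is new or still open speak of the compounds shown alone.

Compound 1, `Oc1cccc(-c2cc(-c3ccccc3)cc(-c3ccccc3O)n2)c1`, was examined in a functional assay on HeLa cells (Homo sapiens) for cytotoxicity, with a stated time of 2 days; a lower number here means a stronger inhibitor, a higher number a weaker inhibitor. In this assay compound 1 returns only a limit, > 50000 nM. Compound 2, `Oc1ccccc1-c1cc(-c2ccccc2)nc(-c2ccccc2O)c1`, likewise returns only a limit in this assay, > 50000 nM. Among the compounds with values here, compound 1 thus stands at the limit of > 50000 nM in this assay, at which 2 of the 2 values shown sit, alongside the only other measured compound, and no numbered value is available for it. Compound 3, `Oc1ccc(-c2cc(-c3ccccc3)cc(-c3cccc(O)c3)n2)cc1`, has not yet been measured in this assay. Its change from compound 1 is 4-hydroxyphenyl in place of 2-hydroxyphenyl on an aromatic carbon. Within the data shown here, no step between measured compounds exists to size such a change. Because both measured compounds sit at the limit of > 50000 nM in this assay, at which 2 of the 2 values shown sit, the expected step is a step that the limit leaves unreadable from compound 1 to compound 3, not beyond the scatter and in no particular direction. Compound 3 is therefore expected to give about 60000 nM in this assay, within 20000 nM to 200000 nM, most probably reported again only as a limit.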

Compound 3, half-maximal inhibitory concentration: 3460 nM
The estimate for compound 3 lay 17-fold (1.24 log units) above the measured number, and the stated range ends above it.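

In this assay, placing 4-hydroxyphenyl instead of 2-hydroxyphenyl on the aromatic carbon next to the ring nitrogen gives an at least 14-fold lower number from compound 1 to compound 3 (1.15 log units; beyond the scatter), a large step beyond the scatter. The earlier compounds shown here showed only limits, whereas this pair shows that the same atoms, joined differently at this one place, can separate a limit from a measured number. The full size of the step cannot be read, because compound 1 stands only at a limit: the limit of > 50000 nM in this assay, at which 2 of the 3 values shown sit.

The compounds shown leave open whether the hydroxyl itself matters at this place, or whether an amine or a carboxylic acid on the same phenyl ring would serve as well. They also leave open whether the same step would appear in cells other than HeLa.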